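From propoxy to sec-butoxy on the shared core

The source may hold more compounds than are shown below. What is called first, only, known or untested is meant among the compounds shown, and "the series" means these compounds.

Measured so far in a functional assay on the whole organism (strain Sprague-Dawley) for inhibition, with Rattus norvegicus as the target, with a stated time of 10 min; a lower number here means that less compound is needed, a higher number that more compound is needed for the effect:
compound 1 `CCC(C)Oc1ccccc1-c1ncc(C(=O)O)c(=O)[nH]1`: 0.5 mg/kg
compound 2 `CCOC(=O)c1cnc(-c2ccccc2Cl)[nH]c1=O`: 5 mg/kg
compound 3 `CCCOc1ccccc1-c1ncc(C(=O)OCC)c(=O)[nH]1`: 5 mg/kg

Compound 3 stands level with compound 2, and together they hold the highest number of the three. Compound 1 needs less, with a gap beyond the usual scatter. The next compound, compound 4 `CCOC(=O)c1cnc(-c2ccccc2OC(C)CC)[nH]c1=O`, differs from compound 3 in one place: methyl in place of hydrogen on a saturated chain carbon bound to an oxygen on an aromatic ring and a saturated chain carbon, with methyl in place of hydrogen on a saturated chain carbon bound to an oxygen on an aromatic ring and a saturated chain carbon. This turns propoxy to sec-butoxy.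

Within the data shown here, only one measured step bears on this change: no change at the digits printed from compound 2 to compound 3 (within the scatter), with propoxy in place of chloro on an aromatic carbon. Among the measured compounds shown here, no single-place step links compound 1 to the others, so its value sets no size for this change. Going by that one step to compound 3, no shift beyond the scatter is expected in this assay. The expected step is a 1.3-fold lower number from compound 3 to compound 4 (0.10 log units; within the scatter). For compound 4 the estimate is 4 mg/kg, with an expected range from 1.5 mg/kg to 10 mg/kg.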

Compound 4, dose for 50% inhibition: 0.5 mg/kg
Beside the measured number, compound 4's estimate is 8.0-fold (0.90 log units) above it, outside the stated range (below it).
By their numbers in this assay, from the lowest: compounds 1 and 4 (each within the scatter of the next); then compounds 2 and 3 (each within the scatter of the next).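

In this assay the single added methyl on a saturated chain carbon bound to an oxygen on an aromatic ring gives a 10-fold lower number from compound 3 to compound 4 (1.00 log units; beyond the scatter), so this position answers to the change from propoxy to sec-butoxy, which the earlier step of no change at the digits printed from compound 2 to compound 3 (within the scatter) could not show. Sec-butoxy also separates from chloro where propoxy did not, with a 10-fold lower number from compound 2 to compound 4 (1.00 log units; beyond the scatter) as the step. With sec-butoxy in both compounds, ethyl in place of hydrogen on an oxygen next to a carbonyl group gives no change at the digits printed from compound 1 to compound 4 (within the scatter), so the ester and the free carboxylic acid stand together here.

Nothing at hand accounts for the size of the methyl step. The compounds shown leave open whether a longer chain such as hexyloxy or an amine would hold at this place, and whether a free carboxylic acid alongside propoxy would also match its ester.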